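The compounds below may be only part of what the source reports. "The series", "measured", "known", "first", "only" and "open" are said of these compounds alone.

Compound 1 `COCCOc1ccc2c(c1)CCc1c-2c2c(c3c4ccccc4n(CCO)c13)CNC2=O`: 52%
Compound 2 `O=C1NCc2c1c1c(c3c2c2ccccc2n3CCO)CCc2ccccc2-1`: 14%

In an assay on isolated protein for inhibition of mitogen-activated protein kinase kinase kinase 9 (Homo sapiens), tested at 1 uM (on this read-out higher numbers stand for more inhibition at the one concentration tested (going by the name of the read-out) and lower numbers for less inhibition), compound 2 holds the lowest of the two numbers, with compound 1 standing higher. Within the data shown here, the only measured step bears directly on what follows: a number 38 percentage points lower from compound 1 to compound 2 (beyond the scatter), a large loss when the substituent was stripped away. Compound 3 `N#CCOc1ccc2c(c1)CCc1c-2c2c(c3c4ccccc4n(CCO)c13)CNC2=O` carries cyanomethoxy in place of hydrogen on an aromatic carbon, that is, a group of a different kind returns to the same carbon. Because a number 38 percentage points lower from compound 1 to compound 2 (beyond the scatter) was large, a sizeable gain is expected, though a smaller group may not recover all of it. Compound 3 is therefore expected to give 38%, within 20% to 56%, a step of a number 24 percentage points higher from compound 2 to compound 3 (beyond the scatter).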

Compound 3, a percentage reported as inhibition, at one concentration (the size of the read-out at that concentration, not a potency): 30%
Compound 3: middle estimate off by 8 percentage points, on the high side; measured number inside the range.
By their numbers in this assay, from the lowest: compound 2; then compound 3; then compound 1.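

In this assay, among these compounds, cyanomethoxy on this aromatic carbon gives a number 16 percentage points higher from compound 2 to compound 3 (beyond the scatter), so 2-methoxyethoxy is not the only group that improves on hydrogen here. The group's identity still matters, as replacing the end of the chain gives a number 22 percentage points lower from compound 1 to compound 3 (beyond the scatter). Nothing available here explains the difference between these two groups. On these data alone, it remains open whether a chain ending in an amine or a carboxylic acid, or a longer chain ending in methoxy, would exceed compound 1.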